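Dropping the chloro from a picomolar alpha4/beta2 ligand

This account rests on a few compounds, and the source may have more. Where it says the series, first, only, none or still open, it means among the compounds named here.

Compound 1 `CN(c1ccccc1)c1ccc(N2CC3CC(C2)N3)nn1`: 1430 nM
Compound 2 `Clc1cccc(Nc2cncc(N3CC4CC(C3)N4)c2)c1`: 0.124 nM
Compound 3 `Cc1ccc(Nc2ccc(N3CC4CC(C3)N4)cn2)cc1`: 52.1 nM

These three compounds were measured in an assay on cell membranes for displacement of a labelled ligand from Neuronal acetylcholine receptor; alpha4/beta2 (Rattus norvegicus); a lower number here means a stronger inhibitor, a higher number a weaker inhibitor. Compound 2 has the lowest number of the three; its nearest neighbour is compound 3, whose inhibition constant lies well beyond the scatter above it, and compound 1 stands further away still. Compound 2 is therefore the strongest binder among the measured compounds.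

Compound 4 `c1ccc(Nc2cncc(N3CC4CC(C3)N4)c2)cc1` has not yet been measured in this assay. It differs from compound 2 in one place: hydrogen in place of chloro on an aromatic carbon. The same difference, read one bond further out, is 3-chlorophenyl becoming phenyl, the place being on an aromatic carbon of a six-membered aromatic ring of carbon only.

Among the compounds with values here, no measured pair shows this change, so its size must be estimated. Since compound 2 gives 0.124 nM, compound 4 is expected to keep a low inhibition constant, with a step of a 4.8-fold higher number from compound 2 to compound 4 (0.68 log units; beyond the scatter) towards a higher number, somewhat beyond the scatter. Compound 4 is estimated at 0.6 nM, within a range of 0.15 nM to 3 nM.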

Compound 4, inhibition constant: 0.0807 nM
For compound 4 the middle estimate is 7.4-fold (0.87 log units) above the measured one, outside the stated range (below it).
By their numbers in this assay, from the lowest: compounds 4 and 2 (each within the scatter of the next); then compound 3; then compound 1.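

In this assay the step at this position is a 1.5-fold lower number from compound 2 to compound 4 (0.19 log units; within the scatter), so the chlorine atom on this aromatic carbon is not required for the very tight binding seen with compound 2. The 3-chlorophenyl and phenyl forms cannot be told apart in this assay, and compound 4 at 0.0807 nM stands with compound 2 at the top of the series. The earlier compounds shown here could not show this, as none of them formed a single-place pair with compound 2. No evidence is available on what lies behind this result. The compounds shown leave open what an amine, a carboxylic acid or a methoxy group would do on this aromatic carbon, where only chloro and hydrogen are compared. On these data alone, it also remains open whether this single pair holds on other cores, such as that of compound 3.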